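The source may hold more compounds than are shown below. What is called first, only, known or untested is meant among the compounds shown, and "the series" means these compounds.

Measured in an ADME assay on KB cells (Homo sapiens) for cytotoxicity, with a stated time of 48 h; a lower number here means a stronger inhibitor, a higher number a weaker inhibitor:
- compound 1, `C=C1[C@H](C)CCC[C@]1(C)CC/C(C)=C/CC1=C(O)C(=O)C=C(OC)C1=O`, gives > 10 ug/mL, a limit and not a number.
- compound 2, `COC1=CC(=O)C(O)=C(C/C=C(\C)CC[C@@]2(C)CCC=C(C)[C@H]2C)C1=O`, gives > 10 ug/mL, again a limit.
- compound 3, `CC1=CCC[C@H]2[C@](C)(CC3=C(O)C(=O)C=C(N[C@@H](CO)C(=O)O)C3=O)[C@@H](C)CC[C@]12C`, gives 7.6 ug/mL.

Among the compounds with values here, compound 1 thus stands at the limit of > 10 ug/mL in this assay, at which 2 of the 3 values shown sit; the assay reports only that its value lies beyond that limit, so no number is known for it. Compound 3 is the only one of the three with a measured number, and it differs from the other two in carrying an amino acid group on the shared core in place of a methoxy.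

Compound 4, `C=C1[C@H](C)CCC[C@]1(C)CC/C(C)=C/CC1=C(O)C(=O)C=C(N[C@@H](C(=O)O)[C@@H](C)O)C1=O`, is not yet measured. It is built from compound 1 by a single change, ((1-carboxy-2-hydroxypropyl)amino in place of methoxy on a double-bonded ring carbon). The entering group is of the same kind as the amino acid group on compound 3, and compound 3 gives 7.6 ug/mL. Compound 1, by contrast, has only a limit and no measured number.

On that basis the step of an at least 1.2-fold lower number from compound 1 to compound 4 (0.09 log units; that floor lies within the scatter) is expected to bring compound 4 from the limit into the measurable range, towards a lower number, though how large the step is cannot be told because compound 1 has only a limit. Compound 4 is therefore estimated at 8 ug/mL, with a plausible range from 4 ug/mL to 15 ug/mL.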

Compound 4, half-maximal inhibitory concentration: > 10 ug/mL
Compound 4 gave a limit, no number (the forecaster's own chance of this, stated with the estimate: 35%); middle value at least 1.2-fold (0.09 log units) from the limit.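

Compound 1 and compound 4 both rest on a limit and not a number in this assay, so no step between them can be read: the limit of > 10 ug/mL in this assay, at which 3 of the 4 values shown sit.

The compounds shown leave open how far, and in which direction, (1-carboxy-2-hydroxypropyl)amino in place of methoxy on a double-bonded ring carbon moves the value in this assay.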